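Amino to Hydroxy: an Expected Solubility for Compound 3

The compounds below may be only part of what the source reports. "The series", "measured", "known", "first", "only" and "open" are said of these compounds alone.

Of the compounds shown here, two have been measured in a physicochemical assay for solubility, read by spectrophotometry, using the shake flask method, with a stated time of 2 days, at pH 6.5; on this read-out higher numbers stand for higher solubility and lower numbers for lower solubility. Among the compounds with values here, compound 1 `NCCOc1ccc2nc(-c3cn(-c4ccc(O)cc4)nn3)ccc2c1` is one, and compound 2 `NCCOCCOc1ccc2nc(-c3cn(-c4ccc(O)c(F)c4)nn3)ccc2c1` is the other; they differ in more than one place, so no single step connects them. In this assay compound 1 gives 3.7 ug/mL, while compound 2 gives 9.1 ug/mL. Compound 1 thus stands at the lowest of the two numbers, and the nearest number, that of compound 2, sits higher by a gap that goes beyond the scatter of repeated measurements.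

The path followed here runs from compound 1 to compound 3 `OCCOc1ccc2nc(-c3cn(-c4ccc(O)cc4)nn3)ccc2c1`, which has not yet been measured. The change is hydroxy in place of amino on a saturated chain carbon, two bonds along the chain from an oxygen on an aromatic ring. Within the data shown here, no step between measured compounds shows the effect of this exact change, so the only anchor in the measured numbers is the starting value of compound 1.

The step from compound 1 to compound 3 in this assay is expected to be small, a 1.7-fold lower number from compound 1 to compound 3 (0.23 log units; within the scatter), with a modest fall in solubility judged somewhat more likely than a rise, although a result within the scatter would not surprise. Compound 3 is therefore expected to give about 2.2 ug/mL in this assay, within a range from 0.7 ug/mL to 7 ug/mL.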

Compound 3, solubility: 2.6 ug/mL
For compound 3 the middle estimate is 1.2-fold (0.07 log units) below the measured one; low and high end bracket the measured number.
By their numbers in this assay, from the lowest: compounds 3 and 1 (each within the scatter of the next); then compound 2.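

In this assay, the change of amino to hydroxy on a saturated chain carbon, two bonds along the chain from an oxygen on an aromatic ring, now has a measured size: a 1.4-fold lower number from compound 1 to compound 3 (0.15 log units; within the scatter). Within the data shown here, this is the first comparison here between two compounds that differ in one place only, and it isolates the swap of a single nitrogen for a single oxygen while the shared core stays the same. At this position, then, this read-out does not tell 2-aminoethoxy and 2-hydroxyethoxy apart, and no measurement at hand explains that outcome.

From the compounds shown here alone, whether a carboxylic acid or a dimethylamino group at the same chain end would give a step beyond the scatter remains open, as does whether the amino-to-hydroxy change would behave the same way on a longer chain. Compound 2 differs from the other two compounds in more than one place, so the compounds shown cannot separate any part played by its longer chain from any part played by its fluorine in its value of 9.1 ug/mL.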